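The source may report more compounds than this note shows. Statements on the series, on what has been measured and on what is new or still open speak of the compounds shown alone.

In a functional assay on PC-3 cells (Homo sapiens) for antiproliferative activity, read by MTT assay, with a stated time of 72 h (on this read-out higher numbers stand for weaker inhibition and lower numbers for stronger inhibition), compound 1 (`O=C(N/N=C/c1ccc([N+](=O)[O-])cc1)Nc1ccc(Oc2ccnc3[nH]ccc23)c(F)c1`) gives 150 nM and compound 2 (`CCN(CC)CCCn1cccc1/C=N/NC(=O)Nc1ccc(Oc2ccnc3[nH]ccc23)c(F)c1`) gives 2950 nM as the higher of the two numbers, which means weaker inhibition, with a gap beyond the usual scatter. Compound 3 (`CN1CCN(CCCn2cccc2/C=N/NC(=O)Nc2ccc(Oc3ccnc4[nH]ccc34)c(F)c2)CC1`) has not yet been measured. It differs from compound 2 in one place (4-methylpiperazin-1-yl in place of diethylamino on a saturated chain carbon, three bonds along the chain from an aromatic nitrogen), with 4-methylpiperazin-1-yl in place of diethylamino on a saturated chain carbon, three bonds along the chain from an aromatic nitrogen. Among the measured compounds shown here, no measured pair of compounds shows what this exchange does, so the expectation rests on compound 2 at 2950 nM as the closest reference. In this assay no step beyond the scatter is expected, in either direction. The expected change is small (a 1.2-fold lower number from compound 2 to compound 3 (0.07 log units; within the scatter)) and remains an estimate. Compound 3 is estimated at 2500 nM with an expected range from 900 nM to 7000 nM for its measurement.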

Compound 3, half-maximal inhibitory concentration: 2190 nM
Compound 3: the middle estimate sits 1.1-fold (0.06 log units) above what was measured; the range from low to high includes it.
By their numbers in this assay, from the lowest: compound 1; then compounds 3 and 2 (each within the scatter of the next).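

In this assay, among the compounds shown here, the exchange of diethylamino for 4-methylpiperazin-1-yl gives the first direct reading at this position: a 1.3-fold lower number from compound 2 to compound 3 (0.13 log units; within the scatter). On a saturated chain carbon, three bonds along the chain from an aromatic nitrogen, the open diethylamino group and a six-membered non-aromatic ring with 2 hetero atoms therefore cannot be told apart in this read-out, even though the entering group carries more heavy atoms. Nothing available explains why the two groups read alike.

The compounds shown leave open whether the same holds for a morpholine, a piperidine or a carboxylic acid at this chain carbon. Also open, from the compounds shown here alone, is what a shorter or longer chain carrying 4-methylpiperazin-1-yl would give in this assay.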